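The compounds below may be only part of what the source reports. "The series", "measured", "known", "first", "only" and "open" are said of these compounds alone.

Measured so far in an ADME assay on CHO-K1 cells (Cricetulus griseus) for cytotoxicity, read by MTT assay, with a stated time of 24 h; a lower number here means a stronger inhibitor, a higher number a weaker inhibitor:

- Compound 1 `CCCCCCCCCCCC(=O)Nc1nnc(S[C@@H]2O[C@H](COC(C)=O)[C@H](OC(C)=O)[C@H](OC(C)=O)[C@H]2OC(C)=O)s1`: 27700 nM
- Compound 2 `CCCCCCCCCCCCCCCCCC(=O)Nc1nnc(S[C@@H]2O[C@H](CO)[C@H](O)[C@H](O)[C@H]2O)s1`: "not active" (no number reported)
- Compound 3 `CCCCCCCC/C=C\CCCCCCCCCCCC(=O)Nc1nnc(S[C@@H]2O[C@H](COC(C)=O)[C@H](OC(C)=O)[C@H](OC(C)=O)[C@H]2OC(C)=O)s1`: 25200 nM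

In this assay compound 2 is reported as "not active" (no number reported), so there is no figure from which to count a step. Its standing can only be described in those words.

Compound 4 `CCCCCCCCCCCCCC(=O)Nc1nnc(S[C@@H]2O[C@H](CO)[C@H](O)[C@H](O)[C@H]2O)s1` has not been measured yet. It differs from compound 2 only in its long chain: hydrogen in place of butyl on a saturated chain carbon, ten or more bonds along the chain from a carbonyl carbon. In words, this is hydrogen in place of butyl on a saturated chain carbon, ten or more bonds along the chain from a carbonyl carbon.

Among the measured compounds shown here, only one measured step involves a change in the long chain: a 1.1-fold lower number from compound 1 to compound 3 (0.04 log units; within the scatter). That step lies within the scatter. It is indirect evidence, since both of its compounds carry acetyl groups that compound 2 and compound 4 lack.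

With compound 2 at "not active" (no number reported) and that single chain step showing no real shift, no step beyond the scatter is expected here. The likeliest outcome is a similar report without a number. Should a number appear, it is expected to be high. For compound 4 the estimated value is 70000 nM, with an expected range from 30000 nM to 200000 nM.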

Compound 4, half-maximal inhibitory concentration: "not active" (no number reported)
For compound 4 the study gives words and no number; no gap can be computed for the estimate.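

In this assay, among the compounds shown here, compound 2 gives "not active" (no number reported) and compound 4 gives "not active" (no number reported), so no step can be counted between the two. The compounds shown leave open whether hydrogen in place of butyl on the long chain shifts the result in this assay by any amount. No measured evidence bears on this result.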